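This account rests on a few compounds, and the source may have more. Where it says the series, first, only, none or still open, it means among the compounds named here.

The compounds here share a core, seen in compound 1 as `COc1cc(C(O)(C(F)(F)F)C(F)(F)F)cnc1N1CCN(S(=O)(=O)c2ccc(N)nc2)CC1`, in compound 2 as `CC(C)(O)C#Cc1cc(C(O)(C(F)(F)F)C(F)(F)F)cnc1N1CCN(S(=O)(=O)c2ccc(N)nc2)CC1` and in compound 3 as `Cn1cc(-c2cc(C(O)(C(F)(F)F)C(F)(F)F)cnc2N2CCN(S(=O)(=O)c3ccc(N)nc3)CC2)cn1`. In an ADME assay (liver) for metabolic stability, with Liver microsome (Rattus norvegicus) as the target, using microsomes and NADPH, with a stated time of 30 min, tested at 1 uM (a lower number here means slower removal, a higher number faster removal of the compound), compound 3 gives 44 mL.min-1.g-1, the highest of the two numbers, with compound 2 at 16 mL.min-1.g-1. Compound 1 gives only a limit of the assay, < 14 mL.min-1.g-1 (the limit of < 14 mL.min-1.g-1 in this assay, at which 1 of the 3 values shown sits). Compound 4, `Nc1ccc(S(=O)(=O)N2CCN(c3ncc(C(O)(C(F)(F)F)C(F)(F)F)cc3-c3cncc(F)c3)CC2)cn1`, differs from compound 3 by 5-fluoropyridin-3-yl in place of 1-methyl-1H-pyrazol-4-yl on an aromatic carbon. Among the measured compounds shown here, the steps that bear on this are an at least 3.1-fold higher number from compound 1 to compound 3 (0.49 log units; beyond the scatter) and a 2.8-fold higher number from compound 2 to compound 3 (0.44 log units; beyond the scatter), both of which bring in the 1-methyl-1H-pyrazol-4-yl group that now leaves; no measured step shows a 5-fluoropyridin-3-yl entering. One aromatic ring is exchanged for another, and no step beyond the scatter is expected: a 1.3-fold lower number from compound 3 to compound 4 (0.10 log units; within the scatter). Compound 4 is therefore estimated at 35 mL.min-1.g-1, between 15 mL.min-1.g-1 and 80 mL.min-1.g-1.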

Compound 4, intrinsic clearance in microsomes: 19 mL.min-1.g-1
Beside the measured number, compound 4's estimate is 1.8-fold (0.27 log units) above it; low and high end bracket the measured number.
By their numbers in this assay, from the lowest: compounds 2 and 4 (each within the scatter of the next); then compound 3. At a limit, below all of these: compound 1.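

At this position, exchanging one aromatic ring for another is not neutral in this assay: 5-fluoropyridin-3-yl in place of 1-methyl-1H-pyrazol-4-yl gives a 2.3-fold lower number from compound 3 to compound 4 (0.36 log units; beyond the scatter). The higher number of compound 3 therefore does not come with every aromatic ring here. 5-fluoropyridin-3-yl in place of 3-hydroxy-3-methylbut-1-yn-1-yl gives a 1.2-fold higher number from compound 2 to compound 4 (0.07 log units; within the scatter), so these two groups cannot be told apart in this assay. 5-fluoropyridin-3-yl in place of methoxy gives an at least 1.3-fold higher number from compound 1 to compound 4 (0.13 log units; that floor lies within the scatter), a floor set by a limit of the assay, so this step cannot be read: the limit of < 14 mL.min-1.g-1 in this assay, at which 1 of the 4 values shown sits.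

Open, as far as these compounds go, is how a plain phenyl ring or an amine would behave at this position. Also open, from the compounds shown here alone, is whether the fluorine or the ring nitrogen of 5-fluoropyridin-3-yl matters more.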